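Working notes on a sulfonamide series: the step to compound 3

This account rests on a few compounds, and the source may have more. Where it says the series, first, only, none or still open, it means among the compounds named here.

Measured so far in an assay on isolated protein for inhibition of malate dehydrogenase, mitochondrial (Sus scrofa), with stated times of 45 min and 30 min; a higher number here means a weaker inhibitor, a lower number a stronger inhibitor:
compound 1 `Cc1ccc(S(=O)(=O)Nc2ccc3oc(-c4ccccc4)nc3c2)cc1` — > 63000 nM
compound 2 `O=S(=O)(Nc1ccc(-c2nc3ccccc3o2)cc1)c1cccc(O)c1` — > 63000 nM

Compound 1 returns only a limit of this assay, not a number: > 63000 nM. Compound 2 likewise returns only a limit: > 63000 nM. Where compound 1 stands is therefore fixed only from one side; both values shown sit at the same place, as the limit of > 63000 nM in this assay, at which 2 of the 2 values shown sit, records, and no order between compound 1 and compound 2 can be read from them. Among the compounds with values here, no step between measured compounds exists in this set.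

Compound 3 `O=S(=O)(Nc1ccc2oc(-c3ccccc3)nc2c1)c1ccccc1Cl` is not yet measured. It differs from compound 1 by 2-chlorophenyl in place of 4-methylphenyl on a sulfonyl sulfur. Within the data shown here, with every measured value at the limit, there is no measured step to size this change against. The expected step in this assay is a step that the limit leaves unreadable from compound 1 to compound 3, none beyond the scatter, with compound 3 most likely reported as a limit again. Compound 3 is estimated at 80000 nM, within 30000 nM to 250000 nM.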

Compound 3, half-maximal inhibitory concentration: > 63000 nM
Compound 3: only a limit was reported (the forecaster's own chance of this, stated with the estimate: 85%); the middle value is on the limit's open side.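

Compound 3 also returns only a limit, so no step from compound 1 to compound 3 can be read: the limit of > 63000 nM in this assay, at which 3 of the 3 values shown sit.

The compounds shown leave open whether 2-chlorophenyl in place of 4-methylphenyl on a sulfonyl sulfur changes inhibition in this assay at all, and what any compound's actual value is.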